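The source may hold more compounds than are shown below. What is called first, only, known or untested is meant among the compounds shown, and "the series" means these compounds.

Going by the values given here, compound 2 `CCCCc1cccc(N2CCNCC2)n1` gives the only number in a functional assay on the whole organism with Mus musculus as the target, in the maximal electroshock model, with a stated time of 120 min (on this read-out lower numbers stand for an effect already at smaller amounts and higher numbers for an effect only at larger amounts of compound), namely 30 mg/kg. Compound 1 `CC(C)(C)c1cccc(N2CCNCC2)n1` gives only a limit of the assay, > 300 mg/kg. The step of an at least 10-fold lower number from compound 1 to compound 2 (1.00 log units; beyond the scatter) shows that the group on this aromatic carbon matters, since the limit of > 300 mg/kg in this assay, at which 1 of the 2 values shown sits, for compound 1 turned into a number for compound 2. Compound 3 `CCCCSc1cccc(N2CCNCC2)n1` keeps the shared core and differs from compound 2 by butylsulfanyl in place of butyl on an aromatic carbon. Among the compounds with values here, only the step from compound 1 to compound 2 bears on this change, and it concerned a different pair of groups, so a change within or slightly beyond the scatter is expected, with no clear direction. Compound 3 is estimated at 30 mg/kg, between 10 mg/kg and 100 mg/kg, meaning an expected step of no change at the digits printed from compound 2 to compound 3 (within the scatter).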

Compound 3, minimum effective dose: 100 mg/kg
Compound 3: middle estimate off by 3.3-fold (0.52 log units), on the low side, within the range that was stated.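

In this assay, butylsulfanyl in place of butyl gives a 3.3-fold higher number from compound 2 to compound 3 (0.52 log units; beyond the scatter) on this aromatic carbon next to the ring nitrogen, so adding a sulfur to the butyl chain means a larger amount is needed for an effect. Butylsulfanyl in place of tert-butyl still gives an at least 3.0-fold lower number from compound 1 to compound 3 (0.47 log units; beyond the scatter) and thus keeps a measurable effect. Compound 1 remains a limit of the assay, not a number: the limit of > 300 mg/kg in this assay, at which 1 of the 3 values shown sits.

On these data alone, whether a longer chain, a shorter chain or an amine on this carbon would give a lower number stays open.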